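The source may hold more compounds than are shown below. What is called first, only, known or untested is meant among the compounds shown, and "the series" means these compounds.

Within the data shown here, in this series, compound 1 `COc1ccccc1/C=c1\c(=O)[nH]/c(=C/c2cccc(Cl)c2Cl)c(=O)n1C` is the only compound that carries a number in a functional assay on U-937 cells (Homo sapiens) for cytotoxicity, read by CCK-8 assay, with a stated time of 72 h (a lower number here means a stronger inhibitor, a higher number a weaker inhibitor), where compound 1 gives 100 nM. Compound 2 `C=CCn1c(=O)/c(=C\c2ccc(Cl)c(Cl)c2)[nH]c(=O)/c1=C\c1ccccc1` is reported in this assay only as "not active" (no number reported), without a number. Compound 3 `COc1ccccc1/C=c1\c(=O)[nH]/c(=C/c2ccccc2Cl)c(=O)n1C` has not yet been measured in this assay. It differs from compound 1 by hydrogen in place of chloro on an aromatic carbon. Among the measured compounds shown here, no step between measured compounds is available to set the size, so the change is expected to weaken inhibition only modestly, a step of a 2.5-fold higher number from compound 1 to compound 3 (0.40 log units; beyond the scatter) that may sit near the edge of the usual scatter. Compound 3 is accordingly estimated at 250 nM, within a range of 70 nM to 900 nM.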

Compound 3, half-maximal inhibitory concentration: 100 nM
The estimate for compound 3 lay 2.5-fold (0.40 log units) above the measured number, and the stated range covers the measured number.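

Among these compounds, replacing the 2,3-dichlorophenyl group with the 2-chlorophenyl group gives no change at the digits printed from compound 1 to compound 3 (within the scatter) in this assay and provides the first readable step. At this place on the aromatic ring, hydrogen can stand in for chloro without a shift beyond the scatter, which compound 1 alone could not show. No measurement shown here offers a reason for this result.

From the compounds shown here alone, whether an amine or a carboxylic acid at this place would give the same reading remains open. So does the effect of replacing the remaining chloro group of compound 3 with hydrogen.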